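The source may report more compounds than this note shows. Statements on the series, on what has been measured and on what is new or still open speak of the compounds shown alone.

In a functional assay on MCF7 cells (Homo sapiens) for inhibition, read by MTT assay, with a stated time of 72 h (on this read-out lower numbers stand for stronger inhibition of growth and higher numbers for weaker inhibition of growth), compound 1 `COc1ccc(CNCCCNS(=O)(=O)c2cc(C(F)(F)F)cc(C(F)(F)F)c2)cc1OC` gives 1900 nM. Going by the values given here, compound 2 `O=S(=O)(NCCCNCc1cccc(Cl)c1)c1cc(C(F)(F)F)cc(C(F)(F)F)c1`, in which a 1.4-fold higher number from compound 1 to compound 2 (0.14 log units; within the scatter), gives 2600 nM in this assay, and among the two numbers measured so far its only neighbour is compound 1, a step that stays within the scatter. Compound 3 `O=S(=O)(NCCCNCc1ccccc1Cl)c1cc(C(F)(F)F)cc(C(F)(F)F)c1` differs from compound 2 by 2-chlorophenyl in place of 3-chlorophenyl on a saturated chain carbon bound to an amine nitrogen. Among the compounds with values here, no measured step bears on this change; the one step measured, from compound 1 to compound 2, lay within the scatter, so no step beyond the scatter is expected in this assay, only no change at the digits printed from compound 2 to compound 3 (within the scatter). Compound 3 is therefore estimated at 2600 nM, with a range from 1100 nM to 6500 nM.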

Compound 3, concentration for 50% growth inhibition: 8800 nM
Compound 3: the middle estimate sits 3.4-fold (0.53 log units) below what was measured, outside the stated range (above it).
By their numbers in this assay, from the lowest: compounds 1 and 2 (each within the scatter of the next); then compound 3.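

In this assay, 2-chlorophenyl in place of 3-chlorophenyl on a saturated chain carbon bound to an amine nitrogen gives a 3.4-fold higher number from compound 2 to compound 3 (0.53 log units; beyond the scatter), so the place of the chlorine on the ring matters here, which the earlier step within the scatter had not shown. Set against 3,4-dimethoxyphenyl, 2-chlorophenyl gives a 4.6-fold higher number from compound 1 to compound 3 (0.67 log units; beyond the scatter). Nothing available explains this difference. The compounds shown leave open whether the higher number belongs to chlorine itself or would also appear with 2-bromophenyl, and how plain phenyl would compare.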